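Iodo on the phenyl ring of compound 3

The compounds below may be only part of what the source reports. "The series", "measured", "known", "first", "only" and "open" are said of these compounds alone.

Measured in a functional assay on HeLa cells (Homo sapiens) for antiproliferative activity, read by sulforhodamine B assay, with a stated time of 48 h; a higher number here means a weaker inhibitor of growth, a lower number a stronger inhibitor of growth:
- compound 1 `O=C(NNC(=S)Nc1ccccc1)C1=C(Cl)c2ccccc2CCC1`: 3870 nM
- compound 2 `Cc1cc2c(cc1C)C(Cl)=C(c1nnc(Nc3ccccc3)s1)CCC2`: 4920 nM
- compound 3 `ClC1=C(c2nnc(-c3ccccc3)o2)CCCc2ccccc21`: 3220 nM

Compound 3, at 3220 nM, lies within the scatter of both other compounds, so the three values form one band with no order among them.

The next compound is compound 4 `ClC1=C(c2nnc(-c3cccc(I)c3)o2)CCCc2ccccc21`, which has iodo in place of hydrogen on an aromatic carbon, meta to a large group, turning phenyl into 3-iodophenyl: iodo in place of hydrogen on an aromatic carbon.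

Going by the values given here, no measured pair differs in one place only, so the series offers no direct guide to this change. The only indication is the band itself: compound 1 at 3870 nM and compound 2 at 4920 nM differ from compound 3 in more than one place, yet stay within its scatter. No step beyond the scatter is therefore expected in this assay, with only a slight lean towards a lower number. The estimated step is a 1.2-fold lower number from compound 3 to compound 4 (0.09 log units; within the scatter).

For compound 4 the expected value is 2600 nM, with an estimated range from 900 nM to 6500 nM.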

Compound 4, concentration for 50% growth inhibition: 4100 nM
For compound 4 the middle estimate is 1.6-fold (0.20 log units) below the measured one, within the range that was stated.
By their numbers in this assay, from the lowest: compounds 3, 1, 4 and 2 (each within the scatter of the next).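

In this assay, the series now has its first comparison in one place: a 1.3-fold higher number from compound 3 to compound 4 (0.10 log units; within the scatter). Iodo in place of hydrogen on an aromatic carbon, meta to a large group, therefore gives no step beyond the scatter, and turning phenyl into 3-iodophenyl leaves compound 4 in the same band as the other compounds. No measured evidence bears on why this position responds in this way.

Going by these compounds, whether a different group at this place, such as an amine or a carboxylic acid, would give a step beyond the scatter remains open. Also open, on these data alone, is whether iodo elsewhere on the phenyl ring would stay within the same band, since this single pair speaks only for the one position.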